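Working notes on a sulfur-linked side chain

The source may report more compounds than this note shows. Statements on the series, on what has been measured and on what is new or still open speak of the compounds shown alone.

Measured so far in a toxicity assay on GES1 cells (Homo sapiens) for inhibition, read by MTT assay, with a stated time of 72 h (on this read-out lower numbers stand for stronger inhibition and higher numbers for weaker inhibition), as follows
- compound 1 `Cc1cc(N2CC[C@@H](C)[C@@H](N(C)c3ncnc4[nH]ccc34)C2)n2nc(SCc3ccccc3Br)nc2n1` gives > 100000 nM as a limit of the assay
- compound 2 `Cc1nc2nc(SCc3ccc(Cl)cc3)nn2c(N2CC[C@@H](C)[C@@H](N(C)c3ncnc4[nH]ccc34)C2)c1C` gives 99200 nM as a number
- compound 3 `Cc1cc(N2CC[C@@H](C)[C@@H](N(C)c3ncnc4[nH]ccc34)C2)n2nc(SCCc3ccccc3)nc2n1` gives 66200 nM as a number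

In this assay compound 3 at 66200 nM and compound 2 at 99200 nM lie within the scatter of each other, so no order is read between them. The third reading is the limit of > 100000 nM in this assay, at which 1 of the 3 values shown sits, and is a limit, not a number.

Next is compound 4 `Cc1cc(N2CC[C@@H](C)[C@@H](N(C)c3ncnc4[nH]ccc34)C2)n2nc(SCc3ccc(Br)cc3)nc2n1`, not yet measured. The change is 4-bromophenyl in place of benzyl on a saturated chain carbon bound to a sulfur, with 4-bromophenyl in place of benzyl on a saturated chain carbon bound to a sulfur.

Among the compounds with values here, one measured step bears on it, an at least 1.5-fold lower number from compound 1 to compound 3 (0.17 log units; that floor lies within the scatter), and it rests on a limit. Compound 1 carries 2-bromophenyl and compound 4 carries 4-bromophenyl, so this step, read in reverse, is only a loose guide. The expected size is a 1.3-fold higher number from compound 3 to compound 4 (0.11 log units; within the scatter), toward a higher number and probably not beyond the scatter. Compound 4 is estimated at 85000 nM, with an expected range of 40000 nM to 100000 nM in this assay.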

Compound 4, half-maximal inhibitory concentration: 55600 nM
Estimate against measurement, compound 4: 1.5-fold (0.18 log units) above, and the stated range covers the measured number.
By their numbers in this assay, from the lowest: compounds 4, 3 and 2 (each within the scatter of the next). At a limit, above all of these: compound 1.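

In this assay, the step to 4-bromophenyl on a saturated chain carbon bound to a sulfur reads a 1.2-fold lower number from compound 3 to compound 4 (0.08 log units; within the scatter) and so does not separate the two readings. Placing 4-bromophenyl in place of 2-bromophenyl at the same carbon reads an at least 1.7-fold lower number from compound 1 to compound 4 (0.25 log units; that floor lies within the scatter) and gives this side chain a bromine-bearing reading that is a number. The reading of compound 1 remains a limit and not a number: the limit of > 100000 nM in this assay, at which 1 of the 4 values shown sits.

On these data alone, whether an amine, a carboxylic acid or a longer chain at this position would move the reading beyond the scatter stays open. As far as these compounds go, the true size of the step between the two bromophenyl groups also stays open, with only a floor available for it.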